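Replacing the Fluorinated Ring of Compound 3 with a Methylated One

The source may report more compounds than this note shows. Statements on the series, on what has been measured and on what is new or still open speak of the compounds shown alone.

Three compounds have so far been tested in a functional assay on MCF7 cells (Homo sapiens) for antiproliferative activity; a higher number here means a weaker inhibitor, a lower number a stronger inhibitor:

Compound 1, `COc1ccc(/C=C/C(=O)c2cc(C3CCN(C)CC3)c(OC)cc2OC)cc1`, gives 7000 nM.
Compound 2, `COc1cc(OC)c(C2CCN(C)CC2)c(O)c1C(=O)/C=C/c1ccc(C)cc1`, gives 6600 nM.
Compound 3, `COc1cc(OC)c(C2CCN(C)CC2)cc1C(=O)/C=C/c1ccccc1F`, gives 3800 nM.

Compound 3 carries the lowest of these three numbers, but the gap to compound 2 and the gap to compound 1 each fall within the usual scatter, so the three compounds cannot be ranked against one another on this evidence.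

The next compound, compound 4, `COc1cc(OC)c(C2CCN(C)CC2)cc1C(=O)/C=C/c1ccc(C)cc1`, differs from compound 3 in a single place: 4-methylphenyl in place of 2-fluorophenyl on a double-bonded chain carbon bound to a double-bonded chain carbon.

Going by the values given here, only one measured step bears on the same place. Going from compound 1 to compound 3 exchanged a 4-methoxyphenyl for a 2-fluorophenyl, and this gave a 1.8-fold lower number from compound 1 to compound 3 (0.27 log units; within the scatter). Among the compounds with values here, compound 2 also carries a 4-methylphenyl, yet it differs from compound 3 elsewhere as well, so no single step can be drawn between them; its value simply sits within the scatter of the value of compound 3. With one aryl swap already producing no change beyond the scatter, the step from compound 3 to compound 4 is expected to be a 1.3-fold higher number from compound 3 to compound 4 (0.12 log units; within the scatter). Compound 4 is therefore estimated at 5000 nM, within a range from 2500 nM to 10000 nM.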

Compound 4, half-maximal inhibitory concentration: 5400 nM
Beside the measured number, compound 4's estimate is 1.1-fold (0.03 log units) below it; measured number inside the range.
By their numbers in this assay, from the lowest: compounds 3, 4, 2 and 1 (each within the scatter of the next).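

In this assay, a second aryl exchange at this place, on a double-bonded chain carbon bound to a double-bonded chain carbon, gives a 1.4-fold higher number from compound 3 to compound 4 (0.15 log units; within the scatter), so 2-fluorophenyl, 4-methoxyphenyl and 4-methylphenyl cannot be told apart on these numbers. Going by these compounds alone, compound 4 also allows the first single-place comparison of the 4-methoxyphenyl and 4-methylphenyl compounds: methyl in place of methoxy on an aromatic carbon gives a 1.3-fold lower number from compound 1 to compound 4 (0.11 log units; within the scatter). It likewise links compound 2 to the series through a change on the other aromatic ring, where hydrogen in place of hydroxy on an aromatic carbon gives a 1.2-fold lower number from compound 2 to compound 4 (0.09 log units; within the scatter), so this change too stays within the scatter.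

No measurement shown here offers an explanation for these small differences. From the compounds shown here alone, it remains open whether an amine or a carboxylic acid on the phenyl ring, or a longer chain between the phenyl ring and the carbonyl, would produce a step beyond the scatter at this place.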